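The source may report more compounds than this note shows. Statements on the series, on what has been measured and on what is new or still open speak of the compounds shown alone.

Compound 2 `Cc1cncc(CNC(=O)Nc2ccc(S(=O)(=O)c3ccccc3)cc2)c1`: 7 nM
Compound 1 `Cc1ncccc1CNC(=O)Nc1ccc(S(=O)(=O)c2ccccc2)cc1`: 146 nM
Compound 3 `Cc1cncc(CNC(=O)Nc2ccc(S(=O)(=O)N3CCOCC3)cc2)c1`: 40 nM

In an assay on isolated protein for inhibition of Nicotinamide phosphoribosyltransferase (Homo sapiens), read by spectrophotometry, with stated times of 15 min and 30 min (a higher number here means a weaker inhibitor, a lower number a stronger inhibitor), compound 2 gives the lowest number of the three. The nearest is compound 3, reached by a 5.7-fold higher number from compound 2 to compound 3 (0.76 log units; beyond the scatter); the step of a 21-fold lower number from compound 1 to compound 2 (1.32 log units; beyond the scatter) shows that changing the methylpyridine ring alone can shift the result a great deal.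

Compound 4 `O=C(NCc1cnccn1)Nc1ccc(S(=O)(=O)c2ccccc2)cc1` differs from compound 2 by pyrazin-2-yl in place of 5-methylpyridin-3-yl on a saturated chain carbon bound to an amide-type nitrogen. Among the compounds with values here, only the step of a 21-fold lower number from compound 1 to compound 2 (1.32 log units; beyond the scatter) bears on this, as it alters the same ring, and it was large; the step of a 5.7-fold higher number from compound 2 to compound 3 (0.76 log units; beyond the scatter) concerns a different part. Compound 2 already holds the best value here, so compound 4 is expected to give a modestly higher number, a 5.7-fold higher number from compound 2 to compound 4 (0.76 log units; beyond the scatter). The estimate for compound 4 is 40 nM, within a range from 10 nM to 250 nM.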

Compound 4, half-maximal inhibitory concentration: 1300 nM
Compound 4: middle estimate off by 33-fold (1.51 log units), on the low side; measured number outside the range, above it.
By their numbers in this assay, from the lowest: compound 2; then compound 3; then compound 1; then compound 4.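

Moving from a methylpyridine ring to pyrazin-2-yl at this position gives a 190-fold higher number from compound 2 to compound 4 (2.27 log units; beyond the scatter), a larger step than the methyl shift had shown. Even the poorer 2-methylpyridin-3-yl ring does better, with an 8.9-fold higher number from compound 1 to compound 4 (0.95 log units; beyond the scatter), so the ring at this position can do more than fine-tune the result. Nothing available here explains this loss.

The change swaps a ring carbon for nitrogen and also removes the methyl, and these two changes cannot be told apart. A pyridine ring without the methyl would help separate them.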